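Changing the group on the amine nitrogen of compound 3

The source may report more compounds than this note shows. Statements on the series, on what has been measured and on what is new or still open speak of the compounds shown alone.

Compound 1 `CCN(CC)CCCOc1ccc2cc(NC(=O)c3ccc(O)c(CC=C(C)C)c3)c(=O)oc2c1C`, compound 2 `CC(C)=CCc1cc(C(=O)Nc2cc3ccc(OCCCNC(C)C)c(C)c3oc2=O)ccc1O` and compound 3 `CC(C)=CCc1cc(C(=O)Nc2cc3ccc(OCCCNC4CCCCC4)c(C)c3oc2=O)ccc1O` share a core and a chain ending in an amine, and they differ only in the groups on that nitrogen. In a functional assay on MCF7 cells (Homo sapiens) for antiproliferative activity (a higher number here means a weaker inhibitor, a lower number a stronger inhibitor), compound 1, with diethylamino, gives 6390 nM. Compound 2, with isopropylamino, gives 740 nM. Compound 3, with cyclohexylamino, gives 1070 nM. Compound 3 therefore stands level with compound 2, within the scatter, and well under compound 1.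

Compound 4 `CC(C)=CCc1cc(C(=O)Nc2cc3ccc(OCCCNC(C)(C)c4ccccc4)c(C)c3oc2=O)ccc1O` differs from compound 3 in one place: 1-methyl-1-phenylethyl in place of cyclohexyl on an amine nitrogen. The closest evidence is the swap of one group for another on the same nitrogen, a 1.4-fold higher number from compound 2 to compound 3 (0.16 log units; within the scatter). The two larger steps, an 8.6-fold lower number from compound 1 to compound 2 (0.94 log units; beyond the scatter) and a 6.0-fold lower number from compound 1 to compound 3 (0.78 log units; beyond the scatter), both start from diethylamino, which has two groups on the nitrogen besides the chain. Compound 4 has only one, like compound 2 and compound 3, so those steps bear less directly on it. Going by the values given here, no measured compound carries an aromatic ring in this group, which leaves real uncertainty. The expected change is none beyond the scatter, an estimated 1.1-fold higher number from compound 3 to compound 4 (0.05 log units; within the scatter). For compound 4 the estimated value is 1200 nM, with an expected range of 450 nM to 3500 nM.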

Compound 4, half-maximal inhibitory concentration: 1070 nM
Compound 4: the middle estimate sits 1.1-fold (0.05 log units) above what was measured, and the stated range covers the measured number.
By their numbers in this assay, from the lowest: compounds 2, 3 and 4 (each within the scatter of the next); then compound 1.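

In this assay, an aromatic ring is accepted on this amine nitrogen: 1-methyl-1-phenylethyl, with 9 heavy atoms against the 6 of cyclohexyl, gives no change at the digits printed from compound 3 to compound 4 (within the scatter). Adding the phenyl to the isopropyl group also stays inside the usual spread of repeated measurements, at a 1.4-fold higher number from compound 2 to compound 4 (0.16 log units; within the scatter), so neither the ring type nor the larger group separates these compounds. The advantage over diethylamino holds for this new group too, at a 6.0-fold lower number from compound 1 to compound 4 (0.78 log units; beyond the scatter), so the three compounds with a single group on the nitrogen besides the chain sit level with one another and apart from compound 1, the only one here with two.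

Nothing in the data explains why such different groups give such similar numbers, or why compound 1 stands apart. Still open, as far as these compounds go, is how the number would respond to a primary amine with no added carbon group, to a carboxylic acid or hydroxyl group on the new phenyl ring, or to a longer chain between the oxygen and the amine nitrogen.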